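This account rests on a few compounds, and the source may have more. Where it says the series, first, only, none or still open, it means among the compounds named here.

Going by the values given here, compound 1 `CNc1nccc(N2CC[C@H](NC(=O)Nc3ccc(C)c(Cl)c3)C2)n1` is one of three compounds measured in an ADME assay on a cell-free system (plasma, Mus musculus) for protein binding, where compound 1 gives 98.6%, the second largest unbound share of the three. Compound 3 `O=C(Nc1ccc(Cl)c(C(F)(F)F)c1)N[C@H]1CCN(c2ccncn2)C1` gives 99.3%, an unbound share within the scatter of that of compound 1. Compound 2 `CCN1CCN(Cc2ccc(NC(=O)N[C@H]3CCN(c4ccnc(NC)n4)C3)cc2C(F)(F)F)CC1` gives 85.4%, a far larger unbound share, beyond the scatter.

Compound 4 `CNc1nccc(N2CC[C@H](NC(=O)Nc3ccc(OC)cc3)C2)n1` has not been measured yet. It differs from compound 1 in one place: 4-methoxyphenyl in place of 3-chloro-4-methylphenyl on an amide-type nitrogen. Among the compounds with values here, no measured pair shows this change, so its effect is uncertain. A step toward a larger unbound share, beyond the scatter yet smaller than the gap between compound 1 and compound 2, is expected; the expected step is a 3.2-fold higher unbound fraction from compound 1 to compound 4 (0.51 log units; beyond the scatter). Compound 4 is estimated at 95.5%, with a range from 90% to 98.5%.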

Compound 4, plasma protein binding: 82.1%
Compound 4: the middle estimate sits 4.0-fold (0.60 log units) (unbound fraction) below what was measured, outside the stated range (below it).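

In this assay, 4-methoxyphenyl in place of 3-chloro-4-methylphenyl on the amide-type nitrogen gives a 13-fold higher unbound fraction from compound 1 to compound 4 (1.11 log units; beyond the scatter) and leaves the core of compound 1 unchanged. Going by these compounds alone, this is the first direct view of this position, as the earlier compounds differ from each other in more than one place, and it shows that this single change can move the free share by a large step. Nothing measured here explains the size of that step.

The compounds shown leave open whether the step follows from the methoxy group arriving or from the chlorine and methyl leaving. A plain phenyl or a 4-hydroxyphenyl on the same nitrogen would be further points for telling these apart.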